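The source may report more compounds than this note shows. Statements on the series, on what has been measured and on what is new or still open speak of the compounds shown alone.

Working notes on the series; measured so far:
compound 1 `O=C(O)Cc1sc(CS(=O)(=O)c2ccc(Cl)cc2)nc1-c1ccc(Cl)cc1`: 730 nM
compound 2 `O=C(O)Cc1sc(C(c2ccc(F)cc2)c2ccc(F)cc2)nc1-c1ccco1`: 140 nM

Both numbers come from an in vitro functional assay on HEK285-7 cells for antagonist activity at prostaglandin D2 receptor 2 (Homo sapiens), read by BRET and beta-arrestin recruitment; a lower number here means a stronger inhibitor, a higher number a weaker inhibitor. Compound 2 holds the lower of the two values; compound 1 sits higher, and that gap is beyond the usual scatter of this assay. Compound 3 `O=C(O)Cc1sc(C(c2ccc(F)cc2)c2ccc(F)cc2)nc1-c1ccnc(O)c1` is the next compound, not yet measured. It differs from compound 2 in one place: 2-hydroxypyridin-4-yl in place of furan-2-yl on an aromatic carbon. Within the data shown here, no measured pair in this set shows that change, so there is no step to lean on. The expected step is a 2.1-fold higher number from compound 2 to compound 3 (0.33 log units; beyond the scatter), a modest move toward a higher number, possibly no more than the scatter. Compound 3 is estimated at 300 nM, with a range from 100 nM to 1200 nM.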

Compound 3, half-maximal inhibitory concentration: 890 nM
The estimate for compound 3 lay 3.0-fold (0.47 log units) below the measured number; measured number inside the range.
By their numbers in this assay, from the lowest: compound 2; then compounds 1 and 3 (each within the scatter of the next).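

In this assay, this aromatic carbon next to the ring nitrogen is sensitive to its substituent: 2-hydroxypyridin-4-yl in place of furan-2-yl gives a 6.4-fold higher number from compound 2 to compound 3 (0.80 log units; beyond the scatter) in this single pair. The change alters ring size, ring heteroatoms and hydrogen-bond donor count together, and this pair cannot separate them. No measured data bear on the reason for the step.

On these data alone, it remains open whether the hydroxyl group or the six-membered ring carries the step. Pyridin-4-yl and phenyl at this position would help separate the two.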